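This account rests on a few compounds, and the source may have more. Where it says the series, first, only, none or still open, it means among the compounds named here.

Compound 3 `FC(F)(F)c1cc(NC[C@H]2CCCCN2)c2cn[nH]c2c1` gives 90% in an assay for inhibition of Tryptophan 2,3-dioxygenase (Homo sapiens), with stated times of 10 min and 60 min, tested at 100 uM; on this read-out higher numbers stand for a stronger effect at the one concentration tested and lower numbers for a weaker effect. Among the measured compounds shown here, on the three numbers so far it stands second highest: compound 1 `Oc1ccc(CNc2cc(C(F)(F)F)cc3[nH]ncc23)cc1` gives 91%, and the step of a number 1 percentage points lower from compound 1 to compound 3 (within the scatter) lies within the scatter, so no order is claimed between these two. Compound 2 `FC(F)(F)c1cc(NCC2CNC2)c2cn[nH]c2c1` gives 49%, and the step of a number 41 percentage points higher from compound 2 to compound 3 (beyond the scatter) is large; likewise the step of a number 42 percentage points lower from compound 1 to compound 2 (beyond the scatter) is large. Compound 4 `Nc1cccc(CNc2cc(C(F)(F)F)cc3[nH]ncc23)c1` differs from compound 3 by 3-aminophenyl in place of piperidin-2-yl on a saturated chain carbon bound to a nitrogen on an aromatic ring.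

For the measured compounds named here, two measured steps bear on this change. The step from compound 1 to compound 3 shows that a six-membered aromatic ring of carbon only and piperidin-2-yl at this place give numbers within the scatter of each other, while the steps involving compound 2 show that azetidin-3-yl falls well short. Going by the values given here, compound 4 returns to an aromatic ring of carbon only, carrying one hydrogen-bond donor and one hydrogen-bond acceptor as the leaving group does, so the nearest precedent is compound 1. The step of a number 5 percentage points lower from compound 3 to compound 4 (within the scatter) is therefore expected to stay within the scatter, with some allowance for the 3-aminophenyl not yet having been tried. Compound 4 is expected to give 85%, between 62% and 97%.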

Compound 4, a percentage reported as inhibition, at one concentration (the size of the read-out at that concentration, not a potency): 89%
For compound 4 the middle estimate is 4 percentage points below the measured one; the range from low to high includes it.
By their numbers in this assay, from the lowest: compound 2; then compounds 4, 3 and 1 (each within the scatter of the next).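

In this assay, the step of a number 1 percentage points lower from compound 3 to compound 4 (within the scatter) and the step of a number 2 percentage points lower from compound 1 to compound 4 (within the scatter) place 3-aminophenyl level with both piperidin-2-yl and 4-hydroxyphenyl on the saturated chain carbon bound to a nitrogen on an aromatic ring, so a third group now shares that level and an aromatic ring of carbon only holds it with an amine as well as with a hydroxyl. The step of a number 40 percentage points higher from compound 2 to compound 4 (beyond the scatter) adds another large gap to azetidin-3-yl, which leaves that group as the only one of the four that stands apart at this place. Nothing measured on these compounds accounts for either the shared level or the gap.

A read-out at one concentration cannot say whether compound 1, compound 3 and compound 4 would differ in effect at any other concentration. Also open, going by these compounds, is what an unsubstituted phenyl or a carboxylic acid in place of the amine on that ring would give at this place, and whether pyrrolidin-2-yl would fall with the azetidin-3-yl or with the larger rings.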